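Aryl variation on the shared core: outlook for compound 4

A few compounds are considered here, and "the series" means these few. Any claim that something is new, unique, unknown or untested is made for them only; others in the source may bear on it.

compound 1 `c1ccc2c(-c3cn4ccnc4c(-c4ccc5ncn(C6CCCCC6)c5c4)n3)cccc2c1` — a functional assay on SN12C cells (Homo sapiens) for inhibition, read by sulforhodamine B assay, with a stated time of 48 h, tested at 10 uM; a higher number here means more inhibition at the concentration tested (going by the name of the read-out), a lower number less inhibition: 11.7%
compound 2 `CC(=O)c1ccc(-c2cn3ccnc3c(-c3ccc4ncn(C5CCCCC5)c4c3)n2)cc1` — this assay: 6.33%
compound 3 `COc1ccccc1-c1cn2ccnc2c(-c2ccc3ncn(C4CCCCC4)c3c2)n1` — this assay: 7.73%

In this assay compound 3 stands second highest of the three numbers. Its nearest neighbour is given by a number 1.4 percentage points higher from compound 2 to compound 3 (within the scatter); its furthest by a number 4 percentage points lower from compound 1 to compound 3 (within the scatter). All three measured compounds therefore lie within the scatter of one another, and no order among them can be read.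

Compound 4 `FC(F)(F)c1cccc(-c2cn3ccnc3c(-c3ccc4ncn(C5CCCCC5)c4c3)n2)c1` differs from compound 3 in a single exchange on the aromatic carbon of the shared core: 3-(trifluoromethyl)phenyl in place of 2-methoxyphenyl on an aromatic carbon

Three exchanges of the aryl group on this same aromatic carbon have been measured: a number 5.4 percentage points lower from compound 1 to compound 2 (within the scatter), a number 4 percentage points lower from compound 1 to compound 3 (within the scatter) and a number 1.4 percentage points higher from compound 2 to compound 3 (within the scatter). None of them moved the read-out beyond the scatter. The exchange to 3-(trifluoromethyl)phenyl is of the same kind, and the expected step in this assay is accordingly none beyond the scatter, a number 0.3 percentage points higher from compound 3 to compound 4 (within the scatter). Compound 4 is thus estimated at 8% in this assay, with an expected range from 0% to 18%.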

Compound 4, a percentage reported as inhibition, at one concentration (the size of the read-out at that concentration, not a potency): 8.3%
Estimate against measurement, compound 4: 0.3 percentage points below, within the range that was stated.
By their numbers in this assay, from the lowest: compounds 2, 3, 4 and 1 (each within the scatter of the next).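

In this assay, 3-(trifluoromethyl)phenyl replaces 2-methoxyphenyl on this aromatic carbon of the shared core, exchanging a group with a hydrogen-bond acceptor for one without, and the step is a number 0.6 percentage points higher from compound 3 to compound 4 (within the scatter) in a comparison that still separates nothing. The other two steps to the new compound, a number 2 percentage points higher from compound 2 to compound 4 (within the scatter) and a number 3.4 percentage points lower from compound 1 to compound 4 (within the scatter), also stay inside the scatter, so the four aryl groups at this position still fall in no readable order. No evidence on hand bears on this result.

Every aryl group shown rests on carbon-only aromatic rings, and whether a pyridine ring, a carboxylic acid or an aminomethyl substituent here would move the read-out in this assay beyond the scatter remains open. The same holds for a longer alkyl chain in place of the aryl group.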